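Cytotoxicity of a Macrocyclic Series: Sulfonyl Group Exchange

The source may report more compounds than this note shows. Statements on the series, on what has been measured and on what is new or still open speak of the compounds shown alone.

Measured compounds:
- compound 1, `CCC1(S(=O)(=O)NC(=O)[C@@]23C[C@H]2/C=C\CCCCN(C)C(=O)N[C@@H](CCOc2cc(-c4nc(C(C)C)cs4)nc4c(Cl)c(OC)ccc24)C(=O)N3)CC1`, 49300 nM
- compound 2, `COc1ccc2c(OCC[C@@H]3NC(=O)N(C)CCCCC/C=C\[C@@H]4C[C@@]4(C(=O)NS(=O)(=O)C4CC4)NC3=O)cc(-c3ccccc3)nc2c1`, 53000 nM
- compound 3, `COc1ccc2c(OCC[C@@H]3NC(=O)N(C)CCCC/C=C\[C@@H]4C[C@@]4(C(=O)NS(=O)(=O)C4(C)CC4)NC3=O)cc(-c3nc(C(C)C)cs3)nc2c1C`, 31900 nM

Three macrocycles sharing one core have been tested in an ADME assay on cells (Homo sapiens) for activation; a higher number here means that more compound is tolerated, a lower number that less compound is tolerated. Compound 1 gives 49300 nM, compound 2 gives 53000 nM and compound 3 gives 31900 nM. The number for compound 1 lies within the usual scatter of both compound 2 and compound 3, so the three compounds cannot be told apart in this assay on these data.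

The next compound, compound 4, `COc1ccc2c(OCC[C@@H]3NC(=O)N(C)CCCC/C=C\[C@@H]4C[C@@]4(C(=O)NS(=O)(=O)N4CCOCC4)NC3=O)cc(-c3nc(C(C)C)cs3)nc2c1Cl`, is made from compound 1 by one change: morpholin-4-yl in place of 1-ethylcyclopropyl on a sulfonyl sulfur. Going by the values given here, no measured pair here shows what such an exchange on the sulfonyl sulfur does to tolerance in this assay, and the three measured compounds, differing at several places, all sit within the scatter of one another. The expected step from compound 1 to compound 4 is therefore none beyond the scatter, a 1.1-fold lower number from compound 1 to compound 4 (0.04 log units; within the scatter). Compound 4 is estimated at 45000 nM, with a range from 20000 nM to 100000 nM.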

Compound 4, half-maximal cytotoxic concentration: 26400 nM
Compound 4: the middle estimate sits 1.7-fold (0.23 log units) above what was measured, within the range that was stated.
By their numbers in this assay, from the lowest: compounds 4, 3, 1 and 2 (each within the scatter of the next).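

Going by these compounds alone, compound 1 and compound 4 are the first pair that differ in one place only, so the sulfonyl sulfur can now be read on its own: morpholin-4-yl in place of 1-ethylcyclopropyl gives a 1.9-fold lower number from compound 1 to compound 4 (0.27 log units; within the scatter) in this assay. In this pair, a six-membered ring with 2 hetero atoms and a three-membered ring of carbon only therefore cannot be told apart at this position, despite the different ring size and atoms. No accompanying measurement bears on this result.

As far as these compounds go, one pair says little about the position as a whole, so it remains open whether a dimethylamino group or a chain ending in a carboxylic acid on the sulfonyl sulfur would also stay within the scatter. From the compounds shown here alone, it also remains open whether the same exchange would give a similar step on a compound with other groups elsewhere on the shared core.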